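From chloro to trifluoromethyl: notes on compound 4

The source may hold more compounds than are shown below. What is called first, only, known or untested is meant among the compounds shown, and "the series" means these compounds.

Measured so far in an ADME assay (liver) for metabolic stability, with Liver microsome (Rattus norvegicus) as the target, read by LC-MS, using microsomes, with a stated time of 30 min, tested at 4 uM (a lower number here means that less of the compound is left, a higher number that more of the compound is left), are three compounds
Compound 1 `COCCn1c(-c2ccccc2Cl)nc2c(N3CCN4C(=O)CCC4C3)nc(C)nc21` gives 91%
Compound 2 `CCN1CCN(c2nc(C)nc3c2nc(-c2ccccc2Cl)n3CC2CCOCC2)CC1` gives 80%
Compound 3 `Cc1nc(N2CCN(C)CC2)c2nc(-c3cccc(Cl)c3)n(C3CCOCC3)c2n1` gives 45%

Compound 3 stands lowest of the three at 45% while compound 2 and compound 1 both lie higher, beyond the usual scatter. For the measured compounds named here, these three compounds differ from one another in more than one place, so no measured step isolates a single change, and the gaps cannot be assigned to any one group.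

The next compound, compound 4 `Cc1nc(N2CCN(C)CC2)c2nc(-c3cccc(C(F)(F)F)c3)n(C3CCOCC3)c2n1`, differs from compound 3 in one substituent (trifluoromethyl in place of chloro on an aromatic carbon). Trifluoromethyl takes the place of chloro on an aromatic carbon, meta to a large group, so 3-chlorophenyl becomes 3-(trifluoromethyl)phenyl. Going by the values given here, the series holds no measured example of this exchange. The expectation therefore starts from compound 3 at 45% and anticipates no step beyond the scatter in this assay with no firm direction. An estimated a number 3 percentage points higher from compound 3 to compound 4 (within the scatter) is expected, and the uncertainty around it is wide. For compound 4 the estimated value is 48% with 30% to 68% as the expected range.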

Compound 4, percent of the compound remaining: 28%
The estimate for compound 4 lay 20 percentage points above the measured number; the whole stated range lies above it.
By their numbers in this assay, from the lowest: compound 4; then compound 3; then compound 2; then compound 1.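

For the compounds shown here, this is the only step that isolates a single change. In this assay, trifluoromethyl in place of chloro on an aromatic carbon, meta to a large group, gives a number 17 percentage points lower from compound 3 to compound 4 (beyond the scatter), so the group at this position matters for how much compound is left, something compound 1 and compound 2 could not show as they differ from compound 3 in more than one place. Nothing measured in the series bears on the reason for this step, which rests on one pair of compounds and supports no wider pattern.

Open, from the compounds shown here alone, is how other groups at this position would read against the 3-chlorophenyl of compound 3 and the 3-(trifluoromethyl)phenyl of compound 4, for instance a nitrile, a methoxy group, an amine or a carboxylic acid. Also open, going by these compounds, is whether the same exchange would give a step of like direction and size with the other groups carried by compound 1 and compound 2 on the shared core.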